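Exposure of an Indane Analogue Projected from Measured Indoles

The source may hold more compounds than are shown below. What is called first, only, known or untested is meant among the compounds shown, and "the series" means these compounds.

Measured compounds:
Compound 1, `CCC(=O)Nc1cc(Nc2ncc(Br)c(Nc3ccc4cc[nH]c4c3)n2)c(OC)cc1N1CCN(C)CC1`: in an ADME assay on the whole organism (Rattus norvegicus, strain Sprague-Dawley) for pharmacokinetics, read by LC-MS, with a stated time of 24 h, at a dose of 10 mg/kg by the oral route (a lower number here means less compound in the circulation, a higher number more compound in the circulation at the dose given), compound 1 gives 53.7 ng.h/mL.
Compound 2, `C=CC(=O)Nc1cc(Nc2ncc(Br)c(Nc3ccc4ccn(C)c4c3)n2)c(OC)cc1N1CCN(C)CC1`: in this assay compound 2 gives 52.3 ng.h/mL.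

Compound 2 holds the lower of the two numbers, but its nearest neighbour, compound 1, lies within the scatter of it, so the two are not separated in any meaningful way and neither can be called the better or worse of the pair in this assay. The two structures differ in two places at once, so nothing is recorded about what either single change does to the area under the curve.

The next compound, compound 3, `C=CC(=O)Nc1cc(Nc2ncc(Br)c(Nc3ccc4c(c3)CCC4)n2)c(OC)cc1N1CCN(C)CC1`, is obtained from compound 2 by one change: 2,3-dihydro-1H-inden-5-yl in place of 1-methyl-1H-indol-6-yl on a nitrogen on an aromatic ring. Going by the values given here, no measured pair carries this change, so no step in this assay can be read from the data. With nothing to point in either direction, a change of no more than the usual scatter is the expectation, and the estimated step of a 1.1-fold higher number from compound 2 to compound 3 (0.02 log units; within the scatter) is accordingly small. Compound 3 is estimated to reach 55 ng.h/mL in this assay, with a range from 20 ng.h/mL to 150 ng.h/mL.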

Compound 3, area under the concentration-time curve: 35.6 ng.h/mL
The estimate for compound 3 lay 1.5-fold (0.19 log units) above the measured number; the range from low to high includes it.
By their numbers in this assay, from the lowest: compounds 3, 2 and 1 (each within the scatter of the next).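

In this assay, the change on a nitrogen on an aromatic ring gives the only single-place step among the compounds shown: with 2,3-dihydro-1H-inden-5-yl in place of 1-methyl-1H-indol-6-yl, the result is a 1.5-fold lower number from compound 2 to compound 3 (0.17 log units; within the scatter). This position therefore accepts an all-carbon group with a five-membered non-aromatic ring in place of a group with a five-membered aromatic ring with 1 hetero atom, with no separation in the area under the curve, even though the hydrogen-bond acceptor counted for the leaving group is gone. No measurement shown here bears on what lies behind this small step.

Going by these compounds, whether a different group at this position, such as a plain phenyl or a ring carrying an amine or a carboxylic acid, would move the area under the curve beyond the scatter remains open. On these data alone, the two differences between compound 1 and compound 2 also cannot be read separately, so the part played by each in this measure stays unknown.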